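Trading a Cyclopropylmethyl Arm for a Nitrile Arm

This account rests on a few compounds, and the source may have more. Where it says the series, first, only, none or still open, it means among the compounds named here.

In an assay on isolated protein for binding affinity to corticotropin-releasing factor receptor 1 (Homo sapiens) (a lower number here means a stronger inhibitor, a higher number a weaker inhibitor), compound 2 `CCCN(CC1CC1)c1nc(C)nc(N(CC)c2ccc(N(C)C)cc2C(F)(F)F)n1` gives 5 nM. Compound 3 `CCN(CC)c1nc(C)nc(N(CC)c2c(Br)cc(OC)cc2OC)n1` gives 10 nM in this assay, and the gap between the two lies within the usual scatter, so neither can be called the stronger. For compound 1 `CCN(c1nc(C)cc(C)n1)c1ccc(C(C)(C)C)cc1Br` the assay reports only > 100 nM, which is a limit of the assay rather than a number; it is the limit of > 100 nM in this assay, at which 1 of the 3 values shown sits. Among the numbers actually measured, compound 2 thus holds the lowest of the two.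

Compound 4 `CCCCN(CC#N)c1nc(C)nc(N(CC)c2ccc(N(C)C)cc2C(F)(F)F)n1` is the next step from compound 2, with butyl(cyanomethyl)amino in place of (cyclopropylmethyl)(propyl)amino on an aromatic carbon. Both arms carry the same count of heavy atoms, but the ring leaves and a nitrile enters. For the measured compounds named here, no measured pair shows what this exchange does in this assay, so the expectation rests on compound 2 alone, at 5 nM. A step of a 1.6-fold higher number from compound 2 to compound 4 (0.20 log units; within the scatter) is expected, no larger than the scatter. Compound 4 is therefore estimated at 8 nM, with a range from 3 nM to 25 nM.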

Compound 4, inhibition constant: 6 nM
For compound 4 the middle estimate is 1.3-fold (0.12 log units) above the measured one, within the range that was stated.
By their numbers in this assay, from the lowest: compounds 2, 4 and 3 (each within the scatter of the next). At a limit, above all of these: compound 1.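

For the compounds shown here, this is the first pair in the set that differs in one place, so it gives the first direct reading of the arm on the aromatic carbon between two ring nitrogen atoms: in this assay, butyl(cyanomethyl)amino in place of (cyclopropylmethyl)(propyl)amino gives a 1.2-fold higher number from compound 2 to compound 4 (0.08 log units; within the scatter), which cannot be told apart from no change. In this pair, then, the three-membered ring is not needed for a value in this range, and an arm with a nitrile and no ring serves as well. Nothing measured here explains why the two arms read alike.

The compounds shown leave open whether an arm ending in an amine, a carboxylic acid or a longer chain would stay in this range. Also open, from the compounds shown here alone, is whether the same exchange would read alike with the dimethylamino or trifluoromethyl group of these two compounds replaced.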